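Replacing a Chain Ester with sec-Butyl: Expected Activity

The source may report more compounds than this note shows. Statements on the series, on what has been measured and on what is new or still open speak of the compounds shown alone.

Measured compounds:
Compound 1, `CC[C@H](C)[C@H](NC(=O)CN(c1nc(Cl)nc2[nH]cnc12)C1CC1)C(=O)O`, 21.4% in a functional assay on the whole organism (Tail, strain ICR) with Mus musculus as the target, in the tail flick test, with a stated time of 120 min, at a dose of 25 umol/kg by the oral route; a higher number here means a stronger effect of the compound at the dose given, a lower number a weaker effect.
Compound 2, `O=C(CN(c1nc(Cl)nc2[nH]cnc12)C1CC1)N[C@@H](CC(=O)OCc1ccccc1)C(=O)OCc1ccccc1`, 12.1% in this assay.
Compound 3, `O=C(CN(c1nc(Cl)nc2[nH]cnc12)C1CC1)N[C@@H](CCC(=O)OCc1ccccc1)C(=O)OCc1ccccc1`, 45.9% in this assay.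

Compound 3 gives the highest of the three numbers: compound 1 lies lower, and compound 2 lower still, both beyond the scatter. Within the data shown here, the only measured step with a single change is a number 33.8 percentage points higher from compound 2 to compound 3 (beyond the scatter), a large rise in this assay.

Compound 4, `CC[C@H](C)[C@H](NC(=O)CN(c1nc(Cl)nc2[nH]cnc12)C1CC1)C(=O)OCc1ccccc1`, is not yet measured. It differs from compound 3 by sec-butyl in place of 2-(benzyloxycarbonyl)ethyl on a saturated chain carbon bound to an amide-type nitrogen and a carbonyl carbon. Among the measured compounds shown here, no measured step covers this exchange. For the measured compounds named here, compound 4 shares its sec-butyl with compound 1, which gives 21.4%, while compound 3, carrying the longer chain ester, gives 45.9%; the one step known, from compound 2 to compound 3, concerns the length of that ester chain and not its removal. On this basis compound 4 is expected to fall between the numbers of compound 1 and compound 3, with a number 15.9 percentage points lower from compound 3 to compound 4 (beyond the scatter) as the estimated step. The estimate for compound 4 is 30%, with a range from 10% to 55%.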

Compound 4, a percentage reported as activity, at one dose (the size of the read-out at that dose, not a potency): 22%
Compound 4: middle estimate off by 8 percentage points, on the high side, and the stated range covers the measured number.
By their numbers in this assay, from the lowest: compounds 2, 1 and 4 (each within the scatter of the next); then compound 3.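

In this assay the sec-butyl group does not keep the level seen with the longer ester chain at this saturated chain carbon, with a number 23.9 percentage points lower from compound 3 to compound 4 (beyond the scatter), while against the shorter chain there is a number 9.9 percentage points higher from compound 2 to compound 4 (within the scatter), so among these three groups only 2-(benzyloxycarbonyl)ethyl stands apart. With sec-butyl held fixed, benzyl in place of hydrogen on the oxygen next to a carbonyl group gives a number 0.6 percentage points higher from compound 1 to compound 4 (within the scatter), so the benzyl ester and the free carboxylic acid cannot be told apart at this dose and time. Nothing available gives a cause for any of these steps.

Going by these compounds, it remains open what a free carboxylic acid at the end of the ethyl chain would give in place of its benzyl ester. A longer chain carrying the same ester, or an amine at the end of the chain, also remains untested by the compounds shown here.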